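The compounds below may be only part of what the source reports. "The series", "measured", "known", "first", "only" and "open" are said of these compounds alone.

The series rests on a shared core carrying an aryl sulfonyl group and a side chain that varies from compound to compound. Compound 1, `CN(C)CC1CCCc2cc(S(=O)(=O)c3ccccc3)ccc21`, gives in an assay on isolated protein for displacement of a labelled ligand from 5-hydroxytryptamine receptor 6 (Homo sapiens) (on this read-out higher numbers stand for weaker inhibition and lower numbers for stronger inhibition), a value of 0.0631 nM. Compound 2, `NC[C@@H]1CCCc2cc(S(=O)(=O)c3c[nH]c4ccccc34)ccc21`, gives in this assay a value of 0.0501 nM. Compound 3, `O=C(NC[C@@H]1CCCc2cc(S(=O)(=O)c3cccc(F)c3)ccc21)[C@H]1CCCN1`, gives in this assay a value of 0.631 nM, the highest of the three numbers; its nearest neighbour is compound 1, and both compound 1 and compound 2 lie well outside the usual scatter from it.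

The next compound, compound 4, `CN(C)C(=O)NC[C@@H]1CCCc2cc(S(=O)(=O)c3cccc(F)c3)ccc21`, differs from compound 3 in one place: dimethylamino in place of pyrrolidin-2-yl on a carbonyl carbon. The side chain thereby loses its five-membered non-aromatic ring together with its hydrogen-bond donor and acceptor.

Within the data shown here, no measured pair in this set shows what such a change does, so the expectation for compound 4 can only be read from where compound 3 stands. Because compound 3 already gives 0.631 nM, the weakest number shown, compound 4 is expected to move further in the same direction, by a step of a 4.8-fold higher number from compound 3 to compound 4 (0.68 log units; beyond the scatter) that exceeds the scatter. The estimate for compound 4 in this assay is therefore 3 nM, with a likely range from 0.8 nM to 15 nM.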

Compound 4, inhibition constant: 2.51 nM
Beside the measured number, compound 4's estimate is 1.2-fold (0.08 log units) above it; the measured number falls inside the stated range.
By their numbers in this assay, from the lowest: compounds 2 and 1 (each within the scatter of the next); then compound 3; then compound 4.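

Swapping pyrrolidin-2-yl for dimethylamino on a carbonyl carbon gives a 4.0-fold higher number from compound 3 to compound 4 (0.60 log units; beyond the scatter) in this assay, the first step in this set between two compounds that differ in one place, and it shows that the number responds to the group at this position of the side chain. The change removes the five-membered non-aromatic ring, the hydrogen-bond donor, the hydrogen-bond acceptor and the defined stereocentre of the group together, and this single pair does not separate their contributions to the step. Nothing measured here explains why the number rises with this change.

The compounds shown leave open whether a piperidin-2-yl ring, a methylamino group or an aminomethyl group on that carbonyl carbon would give a number closer to that of compound 3 or to that of compound 4, and what the opposite stereoisomer of pyrrolidin-2-yl would give. They also leave open whether the same swap gives a step of similar size when the shared core carries the aryl sulfonyl group of compound 1 or compound 2.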